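The compounds below may be only part of what the source reports. "The series", "measured", "known", "first", "only" and "open" are said of these compounds alone.

Of the compounds shown here, three have so far been measured in a functional assay on A549 cells (Homo sapiens) for cytotoxicity, read by MTT assay, with a stated time of 48 h; a higher number here means a weaker inhibitor, a lower number a stronger inhibitor. Compound 1 `COc1ccc(-c2nnnn2-c2cc(OC)c(OC)c(OC)c2)cc1N` gives 2630 nM in this assay, and compound 2 `COc1cc(C2=NOC(c3cc(OC)c(OC)c(OC)c3)C2)ccc1O` gives 2600 nM. Compound 3 `COc1cc(-n2nnnc2-c2ccc(OCC3CC(c4ccc(C(F)(F)F)cc4)=NO3)c(N)c2)cc(OC)c1OC` gives 1220 nM, the lowest of the three numbers; its gap to compound 2 and its gap to compound 1 both lie beyond the scatter, so compound 3 is the strongest inhibitor among the measured three. No pair of these compounds differs in a single place, so no step between measured compounds can be read from the data.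

Compound 4 `COc1cc(-n2nnnc2-c2ccc(OCC3CC(c4ccc(OC)c(OC)c4OC)=NO3)c(N)c2)cc(OC)c1OC` is not yet measured. It differs from compound 3 in one place: 2,3,4-trimethoxyphenyl in place of 4-(trifluoromethyl)phenyl on a carbon with a double bond to nitrogen. Among the compounds with values here, the measured compounds offer no step that shows what this exchange does. Compound 4 is therefore expected to stay close to compound 3. The expected step is a 1.2-fold lower number from compound 3 to compound 4 (0.09 log units; within the scatter), a change not beyond the scatter in either direction. The estimate for compound 4 in this assay is 1000 nM, within a range from 300 nM to 4000 nM.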

Compound 4, half-maximal inhibitory concentration: 2030 nM
Compound 4: middle estimate off by 2.0-fold (0.31 log units), on the low side, and the stated range covers the measured number.
By their numbers in this assay, from the lowest: compounds 3, 4, 2 and 1 (each within the scatter of the next, the first and the last beyond it).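

In this assay the exchange gives a 1.7-fold higher number from compound 3 to compound 4 (0.22 log units; within the scatter) and so provides the first step read at this position, on a carbon with a double bond to nitrogen. In this one pair, 2,3,4-trimethoxyphenyl, which has more heavy atoms and 3 hydrogen-bond acceptors, takes the place of 4-(trifluoromethyl)phenyl, which has 0, without a change beyond the scatter. No measurement at hand bears on why these two groups read alike.

On these data alone, only these two groups can be compared in this place, so it remains open whether an unsubstituted phenyl, a single methoxy group or a 4-aminophenyl group would also stay within the scatter. As far as these compounds go, it is equally open whether a carboxylic acid or a longer alkyl chain here would shift the number in this assay beyond it.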